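Phenethyl for methoxyphenyl on the chain carbon

This account rests on a few compounds, and the source may have more. Where it says the series, first, only, none or still open, it means among the compounds named here.

Among the compounds with values here, compound 3 `COc1cccc(CNc2nc(N)nc(-c3ccccc3CO)n2)c1` gives 4.11 in a functional assay on cells for positive allosteric modulation of G-protein coupled receptor 68 (Homo sapiens), read by a luciferase reporter and cAMP accumulation, with a stated time of 30 min, at pH 6.8 and pH 8.3, in the presence of a further agent that is not named here (on this read-out higher numbers stand for higher potency (the scale is a negative logarithm) and lower numbers for lower potency), the lowest of the three numbers measured so far. Compound 1 `Nc1nc(NCc2ccccc2F)nc(-c2ccccc2CO)n1` gives 4.27 and compound 2 `Nc1nc(NCc2ccccc2Cl)nc(-c2ccccc2CO)n1` gives 5.07; the step of a number 0.16 log units lower from compound 1 to compound 3 (within the scatter) lies within the scatter, whereas a number 0.96 log units lower from compound 2 to compound 3 (beyond the scatter) and a number 0.80 log units higher from compound 1 to compound 2 (beyond the scatter) go beyond it. Compound 4 `Nc1nc(NCCCc2ccccc2)nc(-c2ccccc2CO)n1` carries phenethyl in place of 3-methoxyphenyl on a saturated chain carbon bound to a nitrogen on an aromatic ring. Only the two steps that exchange the aryl group on that chain carbon bear on this change; neither of them brings in a phenethyl, and they run from a drop inside the scatter to a modest one. For compound 4 the expected step is a number 0.19 log units higher from compound 3 to compound 4 (within the scatter), not beyond the scatter. Compound 4 is estimated at 4.3, between 3.7 and 4.9.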

Compound 4, negative logarithm of the antagonist equilibrium constant: 5.22
The estimate for compound 4 lay 0.92 log units below the measured number; the measured number lies above the stated range.
By their numbers in this assay, from the lowest: compounds 3 and 1 (each within the scatter of the next); then compounds 2 and 4 (each within the scatter of the next).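

At this chain carbon, exchanging the group is no longer only flat or downward: phenethyl gives a number 1.11 log units higher from compound 3 to compound 4 (beyond the scatter) and a number 0.95 log units higher from compound 1 to compound 4 (beyond the scatter). Against 2-chlorophenyl it gives a number 0.15 log units higher from compound 2 to compound 4 (within the scatter), so in this assay these two different groups stand within the scatter of each other. Nothing available here accounts for the phenethyl result.

Open, as far as these compounds go, is whether a longer chain would keep this level, and whether a chloro substituent on the phenethyl ring would add to it. An amine in the chain is equally untested by these compounds.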